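A few compounds are considered here, and "the series" means these few. Any claim that something is new, unique, unknown or untested is made for them only; others in the source may bear on it.

Of the compounds shown here, three sharing a common core have been tested in a functional assay on MCF7 cells (Homo sapiens) for inhibition, read by MTT assay, with a stated time of 48 h, tested at 7.5 ug/mL; on this read-out higher numbers stand for more inhibition of growth at the one concentration tested and lower numbers for less inhibition of growth. Compound 1, `COc1cc2c(c(OC)c1)OCN(c1ccc3oc(-c4ccccc4)cc(=O)c3c1)C2`, carries two methoxy groups on one of its rings; in this assay compound 1 gives 48.9%. Compound 2, `O=c1cc(-c2ccccc2)oc2ccc(N3COc4c(Cl)cc(Cl)cc4C3)cc12`, carries two chlorine atoms in place of those methoxy groups; in this assay compound 2 gives 32.8%. Compound 3, `O=c1cc(-c2ccccc2)oc2cc(N3COc4c(Cl)cc(Cl)cc4C3)ccc12`, has the same chlorinated ring attached at a different point of the core; in this assay compound 3 gives "not active" (no number reported), with no number reported. Among the two measured numbers, compound 1 stands highest, and the gap to compound 2 lies beyond the usual scatter of this assay.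

Compound 4, `COc1cccc2c1OCN(c1ccc3oc(-c4ccccc4)cc(=O)c3c1)C2`, has not yet been measured. It differs from compound 1 by hydrogen in place of methoxy on an aromatic carbon, so it keeps one methoxy group on an aromatic carbon of a six-membered aromatic ring of carbon only, part of a fused system of two rings, and loses the other. Going by the values given here, no measured pair shows the effect of removing a single methoxy group, so the size of the step is unknown; a modest loss, or no step beyond the scatter, is expected. Compound 4 is estimated at 40%, within a range of 20% to 58%, which would mean a step of a number 8.9 percentage points lower from compound 1 to compound 4 (within the scatter).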

Compound 4, percent growth inhibition at one concentration: 32.5%
Compound 4: the middle estimate sits 7.5 percentage points above what was measured, and the stated range covers the measured number.
By their numbers in this assay, from the lowest: compounds 4 and 2 (each within the scatter of the next); then compound 1.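

Going by these compounds alone, until now no two measured compounds differed in only one place, so this pair gives the first direct reading of a single change in this assay: hydrogen in place of methoxy gives a number 16.4 percentage points lower from compound 1 to compound 4 (beyond the scatter), with the rest of the structure unchanged. The methoxy group at this place, on an aromatic carbon meta to the remaining methoxy group and para to a fused ring, therefore matters on this read-out, since removing it alone moves the number beyond the usual scatter. The data hold no measurement that could explain this step.

One open question is whether the methoxy group that compound 4 keeps matters as much, since no compound shown lacks that group alone while keeping the other. It also remains open whether the loss is specific to methoxy, as the compounds shown do not reveal what a hydroxyl group, an amine or a longer chain such as ethoxy would give on this same aromatic carbon.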